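Carbamate oxygen substituent and growth inhibition in selenocyanate series

A few compounds are considered here, and "the series" means these few. Any claim that something is new, unique, unknown or untested is made for them only; others in the source may bear on it.

Of the compounds shown here, three have numbers so far. In a functional assay on MCF7 cells (Homo sapiens) for cytotoxicity, read by MTT assay, with a stated time of 72 h (on this read-out higher numbers stand for weaker inhibition of growth and lower numbers for stronger inhibition of growth), compound 3 `CCOC(=O)Nc1ccc([Se]C#N)cc1` gives 36700 nM. Compound 2 `CCCOC(=O)Nc1ccc([Se]C#N)cc1` gives 34400 nM, and compound 1 `N#C[Se]c1ccc(NC(=O)Oc2ccc(F)cc2)cc1` gives 33300 nM. Compound 3 carries the highest of the three numbers, but neither gap is meaningful: the nearest is compound 2 and the furthest is compound 1, both within the scatter. For the measured compounds named here, the only single-point step among the measured compounds, a 1.1-fold higher number from compound 2 to compound 3 (0.03 log units; within the scatter), is likewise flat.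

Compound 4 `N#C[Se]c1ccc(NC(=O)Oc2ccccc2)cc1` differs from compound 3 in one place: phenyl in place of ethyl on an oxygen next to a carbonyl group. Two pieces of evidence bear on this. Going by the values given here, the step from compound 2 to compound 3 is the only measured change on an oxygen next to a carbonyl group, and it moved nothing. Compound 1, which also bears a six-membered aromatic ring on an oxygen next to a carbonyl group, sits with compounds 2 and 3 inside the scatter. Nothing in the series shows a group on this oxygen shifting the number. The step from compound 3 to compound 4 is therefore expected to be a 1.1-fold lower number from compound 3 to compound 4 (0.05 log units; within the scatter), with no change beyond the scatter. Compound 4 is expected to give about 33000 nM. The range expected for compound 4 runs from 17000 nM to 66000 nM.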

Compound 4, concentration for total growth inhibition: 35900 nM
Estimate against measurement, compound 4: 1.1-fold (0.04 log units) below; the measured number falls inside the stated range.
By their numbers in this assay, from the lowest: compounds 1, 2, 4 and 3 (each within the scatter of the next).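

In this assay, for the compounds shown here, the exchange of ethyl for phenyl on an oxygen next to a carbonyl group is the first direct comparison of a chain with an aromatic ring at this position, and it gives a step that stays within the scatter (a 1.0-fold lower number from compound 3 to compound 4 (0.01 log units; within the scatter)). The comparison with the longer chain reads the same way (a 1.0-fold higher number from compound 2 to compound 4 (0.02 log units; within the scatter)), so across compounds 2, 3 and 4 neither the chain length nor the move from chain to one six-membered aromatic ring separates the numbers. Going by these compounds alone, compound 4 also gives the first reading of a substituent on that ring, and hydrogen in place of fluoro on an aromatic carbon likewise stays within the scatter (a 1.1-fold higher number from compound 1 to compound 4 (0.03 log units; within the scatter)), so compound 1 owes no separation from the others to its fluoro group.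

Still open, going by these compounds, is whether a much longer chain, a benzyl group, a chain ending in an amine or a carboxylic acid on this oxygen, or a methoxy or nitro group on the phenyl ring in place of fluoro, would move the number beyond the scatter. Nothing measured on these compounds offers an explanation for the flat result.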